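From Hydrogen to Cyano in a Weakly Cytotoxic Series

The source may report more compounds than this note shows. Statements on the series, on what has been measured and on what is new or still open speak of the compounds shown alone.

Measured compounds:
Compound 1, `C=CC(=O)N1C(=O)CC(c2ccc(C)cc2)Sc2ccccc21`; in a functional assay on MOLT-4 cells (Homo sapiens) for cytotoxicity, read by CCK-8 assay, with a stated time of 24 h (a higher number here means a weaker inhibitor, a lower number a stronger inhibitor), compound 1 gives 87600 nM.
Compound 2, `C=CC(=O)N1C(=O)CC(c2ccccc2)Sc2ccccc21`; in this assay compound 2 gives 85900 nM.

Among the measured compounds shown here, both compounds are weak inhibitors in this assay, and compound 2 cannot be set apart from compound 1: the single measured step, a 1.0-fold lower number from compound 1 to compound 2 (0.01 log units; within the scatter), lies within the scatter, so the two numbers are to be read as the same.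

Compound 3, `C=CC(=O)N1C(=O)CC(c2ccc(C#N)cc2)Sc2ccccc21`, differs from compound 2 in one place: cyano in place of hydrogen on an aromatic carbon. For the measured compounds named here, the only step that bears on this change is the one between compound 1 and compound 2, which also swaps a substituent on an aromatic carbon of the same ring and which, at a 1.0-fold lower number from compound 1 to compound 2 (0.01 log units; within the scatter), produced no movement beyond the scatter. Nothing measured here shows that a group at that aromatic carbon shifts the read-out, so no step beyond the scatter is expected in this assay for the cyano group either.

Compound 3 is therefore estimated at 80000 nM, with a range of 35000 nM to 200000 nM, which means an expected step of a 1.1-fold lower number from compound 2 to compound 3 (0.03 log units; within the scatter).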

Compound 3, half-maximal inhibitory concentration: 88700 nM
Compound 3: middle estimate off by 1.1-fold (0.04 log units), on the low side, within the range that was stated.
By their numbers in this assay, from the lowest: compounds 2, 1 and 3 (each within the scatter of the next).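

In this assay, the move to cyano on this aromatic carbon gives a step that lies within the scatter (a 1.0-fold higher number from compound 2 to compound 3 (0.01 log units; within the scatter)), and the exchange of methyl for cyano at the same place does too (a 1.0-fold higher number from compound 1 to compound 3 (0.01 log units; within the scatter)). The earlier pair had set only methyl against hydrogen, whereas this result adds a group with a triple bond and a hydrogen-bond acceptor, and the number still cannot be told apart from either of the other two. For these three compounds, then, the choice among hydrogen, methyl and cyano on an aromatic carbon para to a large group leaves the read-out indistinguishable, and nothing at hand bears on the reason for this result.

From the compounds shown here alone, whether an amine, a carboxylic acid or a longer chain at this place would move the number beyond the scatter remains open. Also open, going by these compounds, is whether any step would appear with a group elsewhere on the shared core, for example a propanoyl group in place of the acryloyl group.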